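The compounds below may be only part of what the source reports. "The series", "measured", "known", "first", "only" and "open" are said of these compounds alone.

Compound 1 `COc1ccccc1-c1oc2ccc(NC(C)=O)cc2c(=O)c1O`: 385000 nM
Compound 2 `COc1cccc(-c2oc3ccc(NC(C)=O)cc3c(=O)c2O)c1`: 33300 nM
Compound 3 `COc1ccc(-c2oc3ccc(NC(C)=O)cc3c(=O)c2O)cc1`: not yet measured

Among the compounds with values here, in an ADME assay on MT4 cells (Homo sapiens) for cytotoxicity, read by MTT assay, with a stated time of 4 days (on this read-out lower numbers stand for higher toxicity in this test and higher numbers for lower toxicity in this test), compound 2 gives 33300 nM, the lower of the two numbers so far, while compound 1 gives 385000 nM. The next change leads to compound 3: 4-methoxyphenyl in place of 3-methoxyphenyl on an aromatic carbon. The shared core stays the same, and only the methoxy group on the phenyl changes position. Within the data shown here, one measured step bears on this change: a 12-fold lower number from compound 1 to compound 2 (1.06 log units; beyond the scatter). This large step, beyond the scatter, is 3-methoxyphenyl in place of 2-methoxyphenyl at the same place on the core. It shows that such a change can move the number strongly in this assay, but a single step sets no trend and does not fix a direction for the next change. No step beyond the scatter is therefore expected, though a large step in either direction cannot be excluded. The estimate means a 1.4-fold higher number from compound 2 to compound 3 (0.13 log units; within the scatter), an expected step of modest size. For compound 3 the estimated value is 45000 nM, with an expected range of 13000 nM to 160000 nM.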

Compound 3, half-maximal cytotoxic concentration: 98700 nM
Compound 3: the middle estimate sits 2.2-fold (0.34 log units) below what was measured; measured number inside the range.
By their numbers in this assay, from the lowest: compound 2; then compound 3; then compound 1.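

In this assay, the set now covers all three placements of the methoxy group on the phenyl, and each stands apart from the other two: the change gives a 3.0-fold higher number from compound 2 to compound 3 (0.47 log units; beyond the scatter) and a 3.9-fold lower number from compound 1 to compound 3 (0.59 log units; beyond the scatter) in the notes on this series. The number does not run in one direction along 2-methoxyphenyl, 3-methoxyphenyl and 4-methoxyphenyl, since 3-methoxyphenyl gives the lowest number of the three and 4-methoxyphenyl falls between the other two, so the large fall seen earlier belongs to the 3-methoxyphenyl placement and is only partly kept with 4-methoxyphenyl. No measurement at hand offers a reason for this order of the three placements.

The compounds shown leave open whether the same order of placements would hold for another group on the phenyl, such as ethoxy, hydroxy or chlorine. Also open, going by these compounds, is what a plain phenyl at this place would give, and with it whether each methoxy placement raises or lowers the number relative to the ring with no group on it.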